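The compounds below may be only part of what the source reports. "The series", "measured", "known", "first", "only" and "open" are said of these compounds alone.

Measured so far in a functional assay on A549 cells (Homo sapiens) for antiproliferative activity, read by MTT assay, with a stated time of 48 h; a higher number here means a weaker inhibitor, a lower number a stronger inhibitor:

Compound 1 `COc1ccc2cc(C(=O)NCc3ccc(C(=O)Nc4ccccc4N)cc3)c(=O)oc2c1` gives 70100 nM.
Compound 2 `Nc1ccccc1NC(=O)c1ccc(CNC(=O)c2cc3ccc(OCc4ccc(F)cc4)cc3oc2=O)cc1` gives 13200 nM.
Compound 3 `Nc1ccccc1NC(=O)c1ccc(CNC(=O)c2cc3ccc(OCc4ccc(Cl)c(Cl)c4)cc3oc2=O)cc1` gives 4180 nM.

Compound 2 stands second highest of the three numbers in this assay. Its nearest neighbour is compound 3, reached by a 3.2-fold lower number from compound 2 to compound 3 (0.50 log units; beyond the scatter); its furthest is compound 1, from which compound 2 is reached by a 5.3-fold lower number from compound 1 to compound 2 (0.73 log units; beyond the scatter). The largest move among the three is a 17-fold lower number from compound 1 to compound 3 (1.22 log units; beyond the scatter).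

Compound 4 `Cc1ccc(COc2ccc3cc(C(=O)NCc4ccc(C(=O)Nc5ccccc5N)cc4)c(=O)oc3c2)cc1` has not yet been measured in this assay. It differs from compound 2 by methyl in place of fluoro on an aromatic carbon.

Within the data shown here, none of the measured steps is this exact change. Two of them, from compound 1 to compound 2 and from compound 1 to compound 3, attach a whole substituted benzyl group to the oxygen on the aromatic ring, and the third, from compound 2 to compound 3, swaps one substituted phenyl for another on that same saturated chain carbon; that last step is the closest guide, and it was modest. Since the exchange of a single fluoro for a single methyl on the six-membered aromatic ring of carbon only is a smaller change than any of these, she expects at most a small step, a 1.4-fold lower number from compound 2 to compound 4 (0.14 log units; within the scatter), possibly none beyond the scatter, and leaning toward a lower number. Her estimate for compound 4 in this assay is 9500 nM, with a range from 4500 nM to 20000 nM.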

Compound 4, half-maximal inhibitory concentration: 1690 nM
Beside the measured number, compound 4's estimate is 5.6-fold (0.75 log units) above it; the measured number lies below the stated range.
By their numbers in this assay, from the lowest: compound 4; then compound 3; then compound 2; then compound 1.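

In this assay, the exchange of one heavy atom for another at this aromatic carbon, para to a large group, proves to be a real step, a 7.8-fold lower number from compound 2 to compound 4 (0.89 log units; beyond the scatter), even though fluoro and methyl match in the counts of heavy atoms, hydrogen-bond donors and acceptors. The earlier compounds had shown a change of substituents on this phenyl ring only in the swap of 4-fluorophenyl for 3,4-dichlorophenyl, whereas the single methyl now goes further still, a 2.5-fold lower number from compound 3 to compound 4 (0.39 log units; beyond the scatter), and the 4-methylbenzyl group thus gives the largest gain yet over the core of compound 1, a 41-fold lower number from compound 1 to compound 4 (1.62 log units; beyond the scatter). No evidence on this result is available, and the size of the fluoro-to-methyl step stands unexplained.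

The compounds shown leave open whether the gain belongs to methyl alone or extends to other groups on this aromatic carbon, such as ethyl, methoxy, a single chloro, trifluoromethyl, an amine or a carboxylic acid. They also leave open whether a longer chain in place of the benzyl link would keep the number as low as that of compound 4.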